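Geometry of the Linker: From the Z to the E Isomer

The source may hold more compounds than are shown below. What is called first, only, known or untested is meant among the compounds shown, and "the series" means these compounds.

Compound 1 `Nc1nc(N)c2c(CCc3ccc4ccccc4c3)cccc2n1`: 20 nM
Compound 2 `Nc1nc(N)c2c(/C=C\c3ccc4ccccc4c3)cccc2n1`: 5250 nM

In an assay for inhibition of Dihydrofolate reductase (Rattus norvegicus) (a higher number here means a weaker inhibitor, a lower number a stronger inhibitor), compound 2 gives the highest of the two numbers, its nearest neighbour being compound 1 with a much lower number, a gap beyond the scatter. Compound 3 `Nc1nc(N)c2c(/C=C/c3ccc4ccccc4c3)cccc2n1` differs from compound 2 only in one respect: the two compounds have the same atoms and bonds and differ only in configuration as drawn: 1 of 1 stereo elements differ; a double bond is drawn Z in compound 2 and E in compound 3. Within the data shown here, no step between measured compounds covers this kind of change, so the expectation rests on the spread of the two values shown. The expected step of a 53-fold lower number from compound 2 to compound 3 (1.72 log units; beyond the scatter) is a large fall, well beyond the scatter. Compound 3 is estimated at 100 nM, within 15 nM to 1000 nM.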

Compound 3, half-maximal inhibitory concentration: 3020 nM
Compound 3: the middle estimate sits 30-fold (1.48 log units) below what was measured; measured number above the stated range.
By their numbers in this assay, from the lowest: compound 1; then compounds 3 and 2 (each within the scatter of the next).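

Turning the double bond from Z to E gives a 1.7-fold lower number from compound 2 to compound 3 (0.24 log units; within the scatter), so in this assay the drawn configuration at this linker does not separate the two isomers. This reading compares one change alone: the fact that compounds 2 and 3 differ only in the configuration as drawn Whichever way the double bond is drawn, the printed values of both isomers stand far above that of compound 1, whose saturated linker gives 20 nM. Going by these compounds, what remains open is how a triple bond, an ether linker or a longer saturated chain at this position would read, and whether the naphthalene-bearing end would respond in the same way.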